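The source may hold more compounds than are shown below. What is called first, only, known or untested is meant among the compounds shown, and "the series" means these compounds.

Of the compounds shown here, three share one core and have been tested in an assay on microsomes from brain for inhibition of Fatty-acid amide hydrolase 1 (Rattus norvegicus), read by fluorescence and HPLC, with a stated time of 60 min; a lower number here means a stronger inhibitor, a higher number a weaker inhibitor. Compound 1 `CC(Oc1ccc(Oc2ccc(F)cc2)cc1)C(=O)Cn1nnc(-c2ccccc2)n1` gives 24 nM. Compound 2 `CC(Oc1ccc(Oc2ccc(F)cc2)cc1)C(=O)Cn1nnc(-c2ccc(Cl)cc2)n1` gives 42 nM in this assay, and compound 3 `CC(Oc1ccc(Oc2ccc(Cl)cc2)cc1)C(=O)Cn1nnc(-c2ccc(Cl)cc2)n1` gives 76 nM. Compound 2 stands second highest of the three numbers, yet both neighbours sit within the scatter: the step of a 1.8-fold higher number from compound 1 to compound 2 (0.24 log units; within the scatter) and the step of a 1.8-fold higher number from compound 2 to compound 3 (0.26 log units; within the scatter) are each too small to count as a real change.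

Compound 4 `COC(=O)c1ccc(-c2nnn(CC(=O)C(C)Oc3ccc(Oc4ccc(F)cc4)cc3)n2)cc1` has not been measured. It differs from compound 2 in one place: methoxycarbonyl in place of chloro on an aromatic carbon. The step of a 1.8-fold higher number from compound 1 to compound 2 (0.24 log units; within the scatter) bears on it most directly, since it introduced the very chloro that compound 4 now replaces, and it stayed within the scatter; the step of a 1.8-fold higher number from compound 2 to compound 3 (0.26 log units; within the scatter) touched a different ring and also stayed within the scatter. For the measured compounds named here, no measured step swaps chloro for methoxycarbonyl, so the data only show that this part of the molecule has so far moved the numbers little. The expectation is a step of a 1.2-fold higher number from compound 2 to compound 4 (0.08 log units; within the scatter) that stays within the scatter or barely beyond it. Compound 4 is therefore estimated at 50 nM, with a range from 15 nM to 170 nM.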

Compound 4, half-maximal inhibitory concentration: 36 nM
Compound 4: middle estimate off by 1.4-fold (0.14 log units), on the high side; the range from low to high includes it.
By their numbers in this assay, from the lowest: compounds 1, 4, 2 and 3 (each within the scatter of the next, the first and the last beyond it).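

Until now this position, para to a large group, had held only hydrogen or chloro, so it was unclear whether it would accept a group of four heavy atoms with two hydrogen-bond acceptors. Methoxycarbonyl gives a 1.2-fold lower number from compound 2 to compound 4 (0.07 log units; within the scatter) in this assay, and against hydrogen it gives a 1.5-fold higher number from compound 1 to compound 4 (0.18 log units; within the scatter), so hydrogen, chloro and methoxycarbonyl cannot be told apart here and the position accepts a much larger group without a change beyond the scatter. Nothing available explains this result.

Chloro and methoxycarbonyl both carry no hydrogen-bond donors and no net charge, so it remains open whether a carboxylic acid or an amine at the same place would fit equally well. A longer chain on the ester, such as ethoxycarbonyl, is also an open case.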